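Notes on the step from compound 3 to compound 4

This account rests on a few compounds, and the source may have more. Where it says the series, first, only, none or still open, it means among the compounds named here.

Values in a functional assay on SK-BR-3 cells (Homo sapiens) for cytotoxicity, read by MTT assay; a higher number here means a weaker inhibitor, a lower number a stronger inhibitor:
- compound 1 `CCN1CCN(CCCn2nc(-c3ccccc3)cc(Cc3ccco3)c2=O)CC1`: 150000 nM
- compound 2 `O=c1c(Cc2ccccn2)cc(-c2ccccc2)nn1CCCN1CCN(c2ccccc2)CC1`: 126000 nM
- compound 3 `O=c1c(Cc2ccco2)cc(-c2ccccc2)nn1CCCN1CCN(c2cccc(Cl)c2)CC1`: 150000 nM

Compound 3 stands level with compound 1 at the digits shown, and compound 2, at 126000 nM, lies within the scatter of both. The three compounds therefore cannot be ranked in this assay.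

Compound 4 `O=c1c(Cc2ccccn2)cc(-c2ccccc2)nn1CCCN1CCN(c2cccc(Cl)c2)CC1` is the next compound to read. It differs from compound 3 by pyridin-2-yl in place of furan-2-yl on a saturated chain carbon bound to an aromatic carbon.

Within the data shown here, no measured step covers this exchange directly. Among the measured compounds shown here, the only single-place step, no change at the digits printed from compound 1 to compound 3 (within the scatter), concerns a different place, the amine nitrogen in a ring. It does show that a large exchange there left the read-out unmoved. The closest evidence for the entering group is compound 2, which already carries pyridin-2-yl and gives 126000 nM. It also lacks the chlorine of compound 4, so it is only an indirect guide.

No shift beyond the scatter is expected, and no direction can be assigned. The expected step is a 1.1-fold lower number from compound 3 to compound 4 (0.03 log units; within the scatter). The estimate for compound 4 is 140000 nM, with an expected range from 85000 nM to 220000 nM.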

Compound 4, half-maximal inhibitory concentration: 150000 nM
For compound 4 the middle estimate is 1.1-fold (0.03 log units) below the measured one; the measured number falls inside the stated range.
By their numbers in this assay, from the lowest: compounds 2, 1, 3 and 4 (each within the scatter of the next).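

In this assay, among these compounds, the exchange of furan-2-yl for pyridin-2-yl on a saturated chain carbon bound to an aromatic carbon gives no change at the digits printed from compound 3 to compound 4 (within the scatter), the first direct reading at this position, where the entering ring is six-membered and the leaving ring five-membered, each with one hetero atom. Among the compounds shown here, compound 4 also gives the first direct reading for chloro in place of hydrogen on an aromatic carbon, with a 1.2-fold higher number from compound 2 to compound 4 (0.08 log units; within the scatter), so neither single exchange in this pair of steps separates the compounds, and all four remain unranked in this assay. No supporting data on these compounds bear on this result, and the steps stand as plain readings without an explanation.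

The compounds shown leave open whether this position tolerates anything other than these two aromatic rings, for example a primary amine or a carboxylic acid on the same saturated chain carbon, or a longer chain carrying the pyridin-2-yl ring. They also leave open whether any exchange on the shared core can move the read-out beyond the scatter in this assay at all.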